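Replacing 3,5-difluorophenyl on the sulfonamide nitrogen

The source may hold more compounds than are shown below. What is called first, only, known or untested is meant among the compounds shown, and "the series" means these compounds.

In a functional assay on cells (leukaemia cell line, Homo sapiens) for inhibition, read by sulforhodamine B assay, with a stated time of 48 h (on this read-out lower numbers stand for stronger inhibition of growth and higher numbers for weaker inhibition of growth), the measured values are:
compound 1 `O=S(=O)(Nc1ccc(Cl)c(F)c1)c1ccc(-c2cnc(C3CC3)o2)cc1` gives 380 nM
compound 2 `O=S(=O)(Nc1cc(F)cc(F)c1)c1ccc(-c2cnc(C3CC3)o2)cc1` gives 2140 nM

Of these two, compound 2 stands highest at 2140 nM on this read-out. Going by the values given here, the one step bearing on the next change is a 5.6-fold higher number from compound 1 to compound 2 (0.75 log units; beyond the scatter) and is a modest step, seen with 3,5-difluorophenyl in place of 4-chloro-3-fluorophenyl on a sulfonamide nitrogen. The change to compound 3 `Cc1cc(Cl)cc(NS(=O)(=O)c2ccc(-c3cnc(C4CC4)o3)cc2)c1` puts 3-chloro-5-methylphenyl in place of 3,5-difluorophenyl on a sulfonamide nitrogen. Among the compounds with values here, as in compound 1 at 380 nM the group on that nitrogen holds chlorine again, yet no measured compound has a methyl group, so only part of the earlier step is expected to return in this assay. The expected size is a 2.7-fold lower number from compound 2 to compound 3 (0.43 log units; beyond the scatter) toward a lower number, and it rests on a single step. For compound 3 the estimated value is 800 nM, with an expected range from 250 nM to 2500 nM.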

Compound 3, concentration for 50% growth inhibition: 175 nM
Beside the measured number, compound 3's estimate is 4.6-fold (0.66 log units) above it, outside the stated range (below it).
By their numbers in this assay, from the lowest: compound 3; then compound 1; then compound 2.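

In this assay, going by these compounds alone, the group on the sulfonamide nitrogen turns out to allow a larger gain than the one earlier step showed, with a 12-fold lower number from compound 2 to compound 3 (1.09 log units; beyond the scatter). The new group also improves on the chlorine-bearing group of compound 1, with a 2.2-fold lower number from compound 1 to compound 3 (0.34 log units; beyond the scatter), and since 3-chloro-5-methylphenyl holds no fluorine, fluorine on this group is not required for the lowest number of the three. No measurement available here accounts for these steps.

Chlorine and methyl enter together in compound 3, so the compounds shown do not separate the share of each in the gain. On these data alone, it also remains open whether an ethyl or a methoxy group in place of that methyl would keep the number this low.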